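The source may hold more compounds than are shown below. What is called first, only, known or untested is meant among the compounds shown, and "the series" means these compounds.

Of the compounds shown here, three have so far been measured in an assay on isolated protein for inhibition of lysine-specific demethylase 5A (Homo sapiens), read by AlphaLISA, with stated times of 15 min and 1 h, tested at 10 uM; a higher number here means more inhibition at the concentration tested (going by the name of the read-out), a lower number less inhibition. Compound 1 `O=C(O)c1ccnc(N/N=C/c2ccco2)n1` gives 3%. Compound 2 `NNc1nccc(Oc2ccccc2)n1` gives -72%, and compound 3 `NNc1nccc(Oc2ccc(F)cc2)n1` gives -50%. Compound 3 thus stands second highest of the three numbers: its nearest neighbour is compound 2, and compound 1 lies furthest from it. Compound 4 `COc1ccc(Oc2ccnc(NN)n2)cc1` has not yet been measured. It differs from compound 3 in one place: methoxy in place of fluoro on an aromatic carbon. Among the compounds with values here, the only measured step that touches this part of the structure is a number 22 percentage points higher from compound 2 to compound 3 (beyond the scatter), a modest rise beyond the scatter. Within the data shown here, that step put fluoro in place of hydrogen, whereas the present change puts methoxy in place of fluoro, so no measured step shows what methoxy does here. Among the measured compounds shown here, with only one modest related step to go on, the expected change from compound 3 to compound 4 is a number 5 percentage points higher from compound 3 to compound 4 (within the scatter), small and possibly within the scatter. Compound 4 is therefore estimated at -45%, with a range from -75% to -15%.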

Compound 4, a percentage reported as inhibition, at one concentration (the size of the read-out at that concentration, not a potency): -121%
Compound 4: the middle estimate sits 76 percentage points above what was measured, and the stated range ends above it.
By their numbers in this assay, from the lowest: compound 4; then compound 2; then compound 3; then compound 1.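

In this assay, the place on the aromatic carbon para to a group of 9 heavy atoms now responds in both directions, and the size of the change depends on the group placed there. Methoxy gives a large fall whether it replaces fluoro (a number 71 percentage points lower from compound 3 to compound 4 (beyond the scatter)) or hydrogen (a number 49 percentage points lower from compound 2 to compound 4 (beyond the scatter)), whereas fluoro in place of hydrogen had given a modest rise (a number 22 percentage points higher from compound 2 to compound 3 (beyond the scatter)). Nothing available here explains why these two groups move the number in opposite directions.

The compounds shown leave open whether the fall belongs to methoxy alone or also appears with other groups at this place, such as hydroxyl, ethoxy or an amine. Chloro at the same carbon would show whether the modest rise seen with fluoro extends to another halogen.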